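The source may hold more compounds than are shown below. What is called first, only, known or untested is meant among the compounds shown, and "the series" means these compounds.

Measured compounds:
- Compound 1, `CC(C)c1onc(-c2c(Cl)cccc2Cl)c1COc1ccc(N(C)C(=O)c2ccc(C(=O)O)cc2)c(C(F)(F)F)n1`: 208 nM in a functional assay on HEK293 cells for agonist activity at Bile acid receptor (Homo sapiens), read by a luciferase reporter; a lower number here means that less compound is needed, a higher number that more compound is needed for the effect
- Compound 2, `CC(C)c1onc(-c2c(Cl)cccc2Cl)c1COc1ccc(N(C)Cc2ccc(C(=O)NS(C)(=O)=O)cc2)c(C(F)(F)F)n1`: 11 nM

Compound 2 stands at the lower of the two numbers in this assay; compound 1 sits at a higher number, a gap beyond the scatter. Compound 3, `CC(C)c1onc(-c2c(Cl)cccc2Cl)c1COc1ccc(N(C)Cc2ccc(OCC(=O)O)cc2)c(C(F)(F)F)n1`, is not yet measured. It differs from compound 2 in one place: carboxymethoxy in place of (methylsulfonyl)carbamoyl on an aromatic carbon. Among the compounds with values here, no directly measured pair isolates this exchange, so compound 1 and compound 2, which differ in more than one place, cannot be read as a guide to it. Both the leaving and the entering group carry one hydrogen-bond donor, and the benzylic link to the core is kept. A step within the scatter or a modest loss is the expected outcome; the step of a 2.3-fold higher number from compound 2 to compound 3 (0.36 log units; beyond the scatter) is the estimate for this exchange. Compound 3 is therefore expected to give about 25 nM, within a range of 8 nM to 80 nM.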

Compound 3, half-maximal effective concentration: 19 nM
Estimate against measurement, compound 3: 1.3-fold (0.12 log units) above; measured number inside the range.
By their numbers in this assay, from the lowest: compounds 2 and 3 (each within the scatter of the next); then compound 1.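

In this assay, carboxymethoxy in place of (methylsulfonyl)carbamoyl on the aromatic carbon para to a large group gives a 1.7-fold higher number from compound 2 to compound 3 (0.24 log units; within the scatter), so the two groups cannot be told apart at this position, although one has 7 heavy atoms and the other 5. Compound 3 also gives the first one-place link to compound 1: 4-(carboxymethoxy)benzyl in place of (4-carboxyphenyl)carbonyl on the nitrogen gives an 11-fold lower number from compound 1 to compound 3 (1.04 log units; beyond the scatter), a large step, but one that alters the link and the side chain together. Nothing available explains either step.

Still open, on these data alone, is how a carboxylic acid directly on that aromatic carbon would compare with the benzylic link kept, which would separate those two changes. Also open, as far as these compounds go, are a longer chain ending in a carboxylic acid and a primary amide at this position.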